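This account rests on a few compounds, and the source may have more. Where it says the series, first, only, none or still open, it means among the compounds named here.

Series notes. Compound 1 is `CC(C)=CCC/C(C)=C/CC/C(C)=C/CC[C@]1(C)CCc2cc(OC(=O)Nc3ccccc3)c(C)c(C)c2O1` and compound 2 is `CC(C)=CCC/C(C)=C/CC/C(C)=C/CC[C@]1(C)CCc2cc(OC(=O)Nc3ccccc3)cc(C)c2O1`. In a functional assay on MDA-MB-231 cells (Homo sapiens) for antiproliferative activity, read by MTT assay, with a stated time of 96 h (on this read-out higher numbers stand for weaker inhibition and lower numbers for stronger inhibition), compound 1 gives > 10000 nM, a limit of the assay rather than a number. In this assay compound 2 gives > 10000 nM, also a limit. The change between them, (methyl in place of hydrogen on an aromatic carbon), gives a step that the two limits leave unreadable from compound 2 to compound 1. Compound 3 is `CC(C)=CCC/C(C)=C/CC/C(C)=C/CC[C@]1(C)CCc2cc(OC(=O)NC(=O)Oc3ccccc3)c(C)c(C)c2O1`; in this assay compound 3 has "not determined" (no result reported). The difference between the core of compound 3 and that of compound 2 is not broken down here. Compound 4 is `CC(C)=CCC/C(C)=C/CC/C(C)=C/CC[C@]1(C)CCc2c(C)c(OC(=O)NC(=O)Oc3ccccc3)c(C)c(C)c2O1` and differs from compound 3 by methyl in place of hydrogen on an aromatic carbon. This is the same kind of change as from compound 2 to compound 1, but the surroundings differ: in compound 4 the carbon is ortho to a fused ring, ortho to a large group, meta to a fused ring, meta to a methyl group and para to a methyl group; in compound 1 it is ortho to a (phenylcarbamoyl)oxy group, ortho to a methyl group, meta to a fused ring and para to a fused ring. The earlier step has no readable size and compound 3 has no number, so the expectation for compound 4 rests on (the limit of > 10000 nM in this assay, at which 2 of the 3 values shown sit). Compound 4 is expected in this assay at about 15000 nM, between 3000 nM and 60000 nM, most likely again as a limit.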

Compound 4, half-maximal inhibitory concentration: > 10000 nM
Compound 4: only a limit was reported; the forecaster's own chance of this, stated with the estimate: 75%; the middle value does not contradict the limit.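

In this assay compound 4 gives > 10000 nM, a limit and not a number. No new step can be read between compound 3 and compound 4. The compounds shown leave open whether methyl in place of hydrogen on an aromatic carbon changes the read-out of this assay at all, as the values mostly sit at one limit: the limit of > 10000 nM in this assay, at which 3 of the 4 values shown sit.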